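Capping the Pyrrole Nitrogen of Compound 2

The compounds below may be only part of what the source reports. "The series", "measured", "known", "first", "only" and "open" are said of these compounds alone.

Measured so far in a functional assay on SK-OV-3 cells (Homo sapiens) for inhibition, read by CCK-8 assay, with a stated time of 70 h; on this read-out lower numbers stand for stronger inhibition and higher numbers for weaker inhibition:
Compound 1 `c1ccc(COc2ccc(OCCOCCNc3ccccc3)cc2)cc1`: > 100000 nM, which is a limit of the assay.
Compound 2 `c1ccc(COc2ccc(OCCOCCNc3cc[nH]c3)cc2)cc1`: 11300 nM.
Compound 3 `OCCOCCOCCOc1ccc(OCc2ccccc2)cc1`: 59400 nM.

Compound 2 gives the lowest number among the measured compounds; its nearest neighbour is compound 3, separated by a 5.3-fold higher number from compound 2 to compound 3 (0.72 log units; beyond the scatter). Compound 4 `CC(C)(C)OC(=O)n1ccc(NCCOCCOc2ccc(OCc3ccccc3)cc2)c1` differs from compound 2 by tert-butoxycarbonyl in place of hydrogen on an aromatic nitrogen. Going by the values given here, no measured step touches this aromatic nitrogen, so none bears on the change directly. The step of an at least 8.8-fold lower number from compound 1 to compound 2 (0.94 log units; beyond the scatter) shows the number falling when this ring replaces phenyl, and a 5.3-fold higher number from compound 2 to compound 3 (0.72 log units; beyond the scatter) shows it rising when the whole (1H-pyrrol-3-yl)amino group is exchanged. Compound 4 keeps the ring but loses the hydrogen on its nitrogen, so a moderate rise is expected, a 2.7-fold higher number from compound 2 to compound 4 (0.42 log units; beyond the scatter). Compound 4 is estimated at 30000 nM, within 8000 nM to 120000 nM.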

Compound 4, half-maximal inhibitory concentration: 13000 nM
Compound 4: the middle estimate sits 2.3-fold (0.36 log units) above what was measured, and the stated range covers the measured number.
By their numbers in this assay, from the lowest: compounds 2 and 4 (each within the scatter of the next); then compound 3. At a limit, above all of these: compound 1.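

In this assay, tert-butoxycarbonyl in place of hydrogen on the aromatic nitrogen gives a 1.2-fold higher number from compound 2 to compound 4 (0.06 log units; within the scatter) and so leaves compound 2 and compound 4 reading alike. This position therefore accepts a group of 7 heavy atoms, and the hydrogen on this nitrogen is not required for a number at this level. Nothing at hand explains why the two compounds read alike. Still open, from the compounds shown here alone, is whether a small methyl or acetyl group on this nitrogen would read the same. A chain ending in an amine or a carboxylic acid at this position is equally untested here.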